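This account rests on a few compounds, and the source may have more. Where it says the series, first, only, none or still open, it means among the compounds named here.

Measured so far:
compound 1 `O=S(=O)(Nc1ccc(-c2nc3ccccc3o2)cc1)c1ccc(F)c(C(F)(F)F)c1` gives > 63000 nM
compound 2 `O=S(=O)(Nc1ccc2oc(-c3ccccc3)nc2c1)c1ccccc1O` gives > 63000 nM
compound 3 `COc1ccc(Cl)cc1S(=O)(=O)Nc1ccc(-c2nc3ccccc3o2)cc1` gives > 63000 nM

All three values come from an assay on isolated protein for inhibition of malate dehydrogenase, mitochondrial (Sus scrofa), with stated times of 45 min and 30 min; on this read-out lower numbers stand for stronger inhibition and higher numbers for weaker inhibition. For compound 1 the value is a limit of the assay and not a number. For compound 2 the value is likewise a limit, not a measured number. Among the measured compounds shown here, for compound 3 the same holds, so no compound in this set has a defined potency yet; the limit of > 63000 nM in this assay, at which 3 of the 3 values shown sit, sums this up. Compound 2 therefore stands at the limit alongside the other two, and no ordering among the three can be drawn.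

Compound 4 `O=S(=O)(Nc1ccc2oc(-c3ccccc3)nc2c1)c1ccccc1C(F)(F)F` remains to be measured in this assay. It arises from compound 2 by the change (trifluoromethyl in place of hydroxy on an aromatic carbon).

For the measured compounds named here, since no step between measured compounds is available, the expectation rests on the shared outcome of compounds 1, 2 and 3, all of which sit at the limit in this assay. On that basis no step beyond the scatter is expected, and compound 4 is estimated to return a value at or near the limit as well, 100000 nM with a range from 30000 nM to 300000 nM. The step this estimate implies, a step that the limit leaves unreadable from compound 2 to compound 4, is expected to be essentially nil against a limit.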

Compound 4, half-maximal inhibitory concentration: > 63000 nM
Compound 4 gave a limit, no number (the forecaster's own chance of this, stated with the estimate: 85%); the middle value does not contradict the limit.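

Compound 2 and compound 4 both give a limit and not a number in this assay, so no step can be read for trifluoromethyl in place of hydroxy. The compounds shown leave open which structural change, if any, would give a measurable potency in this assay: the limit of > 63000 nM in this assay, at which 4 of the 4 values shown sit.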